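A Ring Swap on the Side Chain of Compound 2

The source may hold more compounds than are shown below. What is called first, only, known or untested is meant among the compounds shown, and "the series" means these compounds.

Compound 1 `CCN(CC)CCn1cccc1/C=N/NC(=O)Nc1ccc(Oc2ccnc3[nH]ccc23)cc1`, compound 2 `O=C(N/N=C/c1cccn1CCCN1CCCCC1)Nc1ccc(Oc2ccnc3[nH]ccc23)cc1` and compound 3 `O=C(N/N=C/c1cccn1CCCN1CCCC1)Nc1ccc(Oc2ccnc3[nH]ccc23)cc1` share a core and differ in one side chain. In a functional assay on MCF7 cells (Homo sapiens) for antiproliferative activity, read by MTT assay, with a stated time of 72 h (a higher number here means a weaker inhibitor, a lower number a stronger inhibitor), compound 1 has the entry "not determined" (no result reported), while compound 2 gives 4690 nM. Compound 2 is therefore the only measured point, and with nothing to compare it against, it cannot yet be ranked as strong or weak. Compound 3 differs from compound 2 in a single place, with pyrrolidin-1-yl in place of piperidin-1-yl on a saturated chain carbon, three bonds along the chain from an aromatic nitrogen. For the measured compounds named here, no measured pair shows what this swap does in this assay, so no step beyond the usual scatter is expected, in either direction. The estimated change is a 1.0-fold lower number from compound 2 to compound 3 (0.02 log units; within the scatter). For compound 3 the expected value is 4500 nM, within an estimated range of 2000 nM to 10000 nM.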

Compound 3, half-maximal inhibitory concentration: 4530 nM
Estimate against measurement, compound 3: 1.0-fold (0.00 log units) below; the measured number falls inside the stated range.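

In this assay, for the compounds shown here, there is now a first step to read at this place, on a saturated chain carbon, three bonds along the chain from an aromatic nitrogen: a 1.0-fold lower number from compound 2 to compound 3 (0.02 log units; within the scatter). The change of piperidin-1-yl to pyrrolidin-1-yl, a six-membered ring to a five-membered one, therefore cannot be told apart in this read-out, so the exact ring size does not matter for this one pair. No outside evidence bears on this result.

Still open, on these data alone, is whether a morpholine ring or a piperazine ring at the same place, or a chain longer than 3-(pyrrolidin-1-yl)propyl, would move the number beyond the scatter. A single step also cannot show whether this side chain matters to the activity at all.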